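The source may hold more compounds than are shown below. What is called first, only, known or untested is meant among the compounds shown, and "the series" means these compounds.

Compound 2, `CCCCCCNc1nc(-c2ccccc2)nc2c1nnn2Cc1ccccc1Cl`, stands lowest of the two numbers shown, giving 31 nM in an assay on Cerebral cortex for displacement of a labelled ligand from adenosine receptor A1 (Bos taurus); a higher number here means a weaker inhibitor, a lower number a stronger inhibitor; its nearest neighbour is compound 1, `CCNc1nc(-c2ccccc2)nc2c1nnn2Cc1ccccc1Cl`, which in this assay gives 463 nM. Among the measured compounds shown here, the one measured step, a 15-fold lower number from compound 1 to compound 2 (1.17 log units; beyond the scatter), rests on butyl in place of hydrogen on a saturated chain carbon, two bonds along the chain from a nitrogen on an aromatic ring. Compound 3, `Clc1ccccc1Cn1nnc2c(NC3CC3)nc(-c3ccccc3)nc21`, carries cyclopropyl in place of hexyl on a nitrogen on an aromatic ring. This change runs against the direction of the measured step, since a group of three carbons closed into a ring replaces the six-carbon chain. Because compound 2 with the hexyl chain gave 31 nM while compound 1 with a shorter chain gave 463 nM, a higher number is expected for compound 3, though a ring is not a chain. Compound 3 is therefore estimated at 150 nM, between 50 nM and 500 nM, an expected step of a 4.8-fold higher number from compound 2 to compound 3 (0.68 log units; beyond the scatter) in this assay.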

Compound 3, inhibition constant: 11 nM
Compound 3: the middle estimate sits 14-fold (1.13 log units) above what was measured; measured number outside the range, below it.
By their numbers in this assay, from the lowest: compound 3; then compound 2; then compound 1.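

Set on the same nitrogen in this assay, cyclopropyl in place of hexyl brings a 2.8-fold lower number from compound 2 to compound 3 (0.45 log units; beyond the scatter), and cyclopropyl in place of ethyl brings a 42-fold lower number from compound 1 to compound 3 (1.62 log units; beyond the scatter). The earlier pair tied the lower number to the longer chain, but compound 3 stands lowest of the three with 3 heavy atoms in a three-membered ring against 6 in hexyl, so the count of carbons alone does not set the order at this position. Nothing in the material offers an explanation for this order.

The compounds shown do not separate the closed ring from its size: an open propyl chain or a cyclobutyl or cyclopentyl ring on this nitrogen would be the direct comparisons. From the compounds shown here alone, whether the same order holds when another part of the shared core changes also remains open.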